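This account rests on a few compounds, and the source may have more. Where it says the series, first, only, none or still open, it means among the compounds named here.

Compound 1 `Cc1nc(N)nc(N[C@@H]2C[C@H](CO)[C@@H](O)[C@H]2O)c1-c1nc2cnccc2s1`: in an ADME assay on cells (Homo sapiens) for cytotoxicity, read by polymerase chain reaction, with a stated time of 3 days (on this read-out higher numbers stand for lower toxicity in this test and lower numbers for higher toxicity in this test), compound 1 gives 25000 nM.
Compound 2 `Cc1nc(N[C@@H](C)c2ccccc2)nc(N[C@@H]2C[C@H](CO)[C@@H](O)[C@H]2O)c1-c1nc2cnccc2s1`: compound 2 gives 25000 nM.

Within the data shown here, compound 1 stands level with compound 2, the only other measured compound. Among the measured compounds shown here, the single measured step, no change at the digits printed from compound 1 to compound 2 (within the scatter), is the one that bears on compound 3 `Cc1nc(NC(C)(C)c2ccccc2)nc(N[C@@H]2C[C@H](CO)[C@@H](O)[C@H]2O)c1-c1nc2cnccc2s1`, which differs from compound 1 by 1-methyl-1-phenylethyl in place of hydrogen on a nitrogen on an aromatic ring. That step was within the scatter, so no step beyond the scatter is expected in this assay when the larger group takes the same place. Compound 3 is estimated at 25000 nM, with a range from 12500 nM to 50000 nM. The expected step is no change at the digits printed from compound 1 to compound 3 (within the scatter).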

Compound 3, half-maximal cytotoxic concentration: 25000 nM
Beside the measured number, compound 3's estimate shows no gap at the digits printed, within the range that was stated.
By their numbers in this assay, from the lowest: compounds 1, 2 and 3 (each within the scatter of the next).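

In this assay, the 1-methyl-1-phenylethyl group on a nitrogen on an aromatic ring gives no change at the digits printed from compound 1 to compound 3 (within the scatter) and, in place of 1-phenylethyl, gives no change at the digits printed from compound 2 to compound 3 (within the scatter) at this position. Two groups carrying a phenyl ring now stand level with hydrogen here, and the added methyl opens no step beyond the scatter. No measured evidence offered here accounts for this flat result. Open, from the compounds shown here alone, is whether a carboxylic acid or a dimethylaminoethyl chain on this nitrogen would move the half-maximal cytotoxic concentration. Changes elsewhere on the shared core also remain open.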